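Single fluorine on the ring-nitrogen aryl group

The source may hold more compounds than are shown below. What is called first, only, known or untested is meant among the compounds shown, and "the series" means these compounds.

Compound 2 `Cc1ccccc1-c1nn(-c2cc(F)ccc2F)cc1CNCCN1CCN(C)CC1` is the starting point. In an ADME assay on Huh-7 cells (Homo sapiens) for cytotoxicity (on this read-out higher numbers stand for lower toxicity in this test and lower numbers for higher toxicity in this test), compound 2 gives > 20000 nM, which is a limit of the assay rather than a number. Compound 1 `Cc1ccccc1-c1nn(Cc2ccc(F)cc2)cc1CNCCN1CCN(C)CC1` gives > 20000 nM in this assay, again a limit. The step between them, a step that the two limits leave unreadable from compound 1 to compound 2, therefore cannot be read, since both values sit at the limit of > 20000 nM in this assay, at which 2 of the 2 values shown sit. Compound 3 `Cc1ccccc1-c1nn(-c2ccc(F)cc2)cc1CNCCN1CCN(C)CC1` differs from compound 2 by 4-fluorophenyl in place of 2,5-difluorophenyl on an aromatic nitrogen. With no readable step to build on, a step that the limit leaves unreadable from compound 2 to compound 3 is expected for compound 3, most likely ending at the same limit. The estimate for compound 3 is 30000 nM, between 15000 nM and 80000 nM.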

Compound 3, half-maximal cytotoxic concentration: > 20000 nM
Compound 3 was reported as a limit (the forecaster's own chance of this, stated with the estimate: 85%); the middle value does not contradict the limit.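

The steps among compound 1, compound 2 and compound 3 cannot be read, because each value is a limit and not a number: the limit of > 20000 nM in this assay, at which 3 of the 3 values shown sit.

From the compounds shown here alone, how far each compound's true value lies past that limit in this assay stays open, so these groups on the ring nitrogen cannot be ranked.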